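Stretching a methyl to an ethyl on the shared core

The source may hold more compounds than are shown below. What is called first, only, known or untested is meant among the compounds shown, and "the series" means these compounds.

Measured so far in an ADME assay on MT4 cells (Homo sapiens) for cytotoxicity, read by MTT assay; a higher number here means that more compound is tolerated, a lower number that less compound is tolerated:
- compound 1, `COc1ccc(CSc2nc(Cc3ccccc3Br)c(C)c(=O)[nH]2)cc1`: 179000 nM
- compound 2, `COc1ccc(CSc2nc(Cc3ccc(Br)cc3)c(C)c(=O)[nH]2)cc1`: > 290000 nM

Going by the values given here, compound 1 stands at the only plain number in this assay. The other value belongs to compound 2, whose result of > 290000 nM is a limit of the assay rather than a measured number (the limit of > 290000 nM in this assay, at which 1 of the 2 values shown sits). Among the compounds with values here, the one measured step, an at least 1.6-fold higher number from compound 1 to compound 2 (0.20 log units; that floor lies within the scatter), swaps 4-bromophenyl for 2-bromophenyl on a saturated chain carbon bound to an aromatic carbon.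

Compound 3, `CCc1c(Cc2ccccc2Br)nc(SCc2ccc(OC)cc2)[nH]c1=O`, differs from compound 1 at a different place: methyl in place of hydrogen on a saturated chain carbon bound to an aromatic carbon, which, seen one bond further out, reads as methyl to ethyl. Within the data shown here, no measured step touches this part of the molecule, so the single step from compound 1 to compound 2 gives no direct guidance. With so small an addition and no evidence pointing either way, no step beyond the scatter is expected in this assay, and the estimated step is a 1.0-fold higher number from compound 1 to compound 3 (0.00 log units; within the scatter). Compound 3 is therefore expected to give about 180000 nM, within a range from 90000 nM to 360000 nM.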

Compound 3, half-maximal cytotoxic concentration: 165000 nM
Estimate against measurement, compound 3: 1.1-fold (0.04 log units) above; the range from low to high includes it.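

In this assay, going by these compounds alone, stretching methyl to ethyl on the shared core gives a 1.1-fold lower number from compound 1 to compound 3 (0.04 log units; within the scatter), so this position, which no earlier step touched, takes one added carbon with no change that can be told from the scatter. This reading rests on two plain numbers, whereas the earlier step, which moved the bromine on the phenyl ring, ended in compound 2 at a limit of the assay and not at a number. Nothing shown gives a reason for this outcome at this position.

From the compounds shown here alone, one added carbon says little about how far the position can be stretched, so it stays open what a longer chain such as propyl or butyl, a branched group such as isopropyl, or an amine or a carboxylic acid would do at the same place. This change is also shown only with 2-bromophenyl, which leaves open whether ethyl would give the same result together with the 4-bromophenyl of compound 2.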